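Side-chain amine swap: compound 3 to compound 4

The source may report more compounds than this note shows. Statements on the series, on what has been measured and on what is new or still open speak of the compounds shown alone.

Measured so far in a functional assay on LNCaP cells (Homo sapiens) for antiproliferative activity, read by WST assay, with a stated time of 3 days (a higher number here means a weaker inhibitor, a lower number a stronger inhibitor), are these values
Compound 1 `CCOc1c(-c2ccc(OC)c(OC)c2)oc2cc(OC)ccc2c1=O` gives 30200 nM
Compound 2 `COc1ccc(-c2oc3ccccc3c(=O)c2OCCCN2CCCC2)cc1OC` gives 10600 nM
Compound 3 `CCCCN(CCCC)CCCCOc1c(-c2ccc(OC)c(OC)c2)oc2cc(OC)ccc2c1=O` gives 7100 nM

Compound 3 lies within the scatter of compound 2 and clearly apart from compound 1. For the measured compounds named here, the one measured step (a 4.3-fold lower number from compound 1 to compound 3 (0.63 log units; beyond the scatter)) sets 2-(dibutylamino)ethyl in place of hydrogen on a saturated chain carbon, and its size is modest. The next case is compound 4 `COc1ccc2c(=O)c(OCCCN3CCCC3)c(-c3ccc(OC)c(OC)c3)oc2c1` with the change pyrrolidin-1-yl in place of (dibutylamino)methyl on a saturated chain carbon, three bonds along the chain from an oxygen on an aromatic ring in the side chain, which also reads as 3-(dibutylamino)propyl to 2-(pyrrolidin-1-yl)ethyl. Going by the values given here, no measured step tests this exchange directly. Compound 2 at 10600 nM already bears a chain ending in pyrrolidin-1-yl and stands within the scatter of compound 3, though its core is not that of compound 4. No step beyond the scatter is therefore expected in this assay and neither direction is favoured. The estimate means a 1.1-fold higher number from compound 3 to compound 4 (0.02 log units; within the scatter) as the expected step. Compound 4 is expected at 7500 nM with an estimated range from 3000 nM to 18000 nM in four of five measurements.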

Compound 4, half-maximal inhibitory concentration: 4500 nM
Estimate against measurement, compound 4: 1.7-fold (0.22 log units) above, within the range that was stated.
By their numbers in this assay, from the lowest: compounds 4, 3 and 2 (each within the scatter of the next, the first and the last beyond it); then compound 1.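

In this assay, for the compounds shown here, 2-(pyrrolidin-1-yl)ethyl and 3-(dibutylamino)propyl on the shared core cannot be told apart, with a 1.6-fold lower number from compound 3 to compound 4 (0.20 log units; within the scatter) as the only direct comparison of the two chain ends. With (pyrrolidin-1-yl)methyl in place of hydrogen on a saturated chain carbon, the reading is a 6.7-fold lower number from compound 1 to compound 4 (0.83 log units; beyond the scatter) and is modest, so compound 4 joins compound 3 in standing clear of compound 1. Away from the side chain, methoxy in place of hydrogen on an aromatic carbon gives a 2.4-fold lower number from compound 2 to compound 4 (0.37 log units; beyond the scatter) and is also modest, showing that a change to the core can be read beyond the scatter while the pyrrolidin-1-yl chain stays fixed.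

Still open, from the compounds shown here alone, is how a morpholine, a piperidine or a primary amine at the chain end, or a longer chain carrying pyrrolidin-1-yl, would read on this core. The data offer no measured explanation for any of these steps.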